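One Swap on an Amine Nitrogen

The source may report more compounds than this note shows. Statements on the series, on what has been measured and on what is new or still open speak of the compounds shown alone.

In an ADME assay on the whole organism (strain Sprague-Dawley) with Rattus norvegicus as the target, read by LC-MS, at a dose of 50 mg/kg by the oral route (on this read-out higher numbers stand for a longer-lived compound and lower numbers for a shorter-lived compound), compound 1 `CCC(CC)O[C@@H]1C=C(C(=O)O)C[C@H](NC(C)=N)[C@H]1NC(C)=O` gives 2.1 h and compound 2 `CCOC(=O)C1=C[C@@H](OC(CC)CC)[C@H](NC(C)=O)[C@@H](N/C(C)=N/O)C1` gives 3.43 h as its reading, so these two numbers lie within the usual scatter of each other. The two compounds differ in more than one place, so they offer no clean single-change comparison. Compound 3 `CCOC(=O)C1=C[C@@H](OC(CC)CC)[C@H](NC(C)=O)[C@@H](N/C(N)=N\O)C1` differs from compound 2 in one place only, on an amine nitrogen whose other neighbour is a saturated ring carbon (a group of 4 heavy atoms (1 carbon, 2 nitrogen, 1 oxygen; no ring) in place of a group of 4 heavy atoms (2 carbon, 1 nitrogen, 1 oxygen; no ring), on an amine nitrogen). Among the compounds with values here, no measured pair shows what this swap does to the reading. With compound 2 at 3.43 h as the closest reference, no shift beyond the scatter is expected in either direction. The estimated step is a 1.1-fold lower number from compound 2 to compound 3 (0.03 log units; within the scatter) and it stays within that scatter. In this assay compound 3 is expected at 3.2 h within a range of 1.7 h to 6 h as its likely reading.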

Compound 3, mean residence time in the Rattus norvegicus assay: 2.8 h
Compound 3: middle estimate off by 1.1-fold (0.06 log units), on the high side; the measured number falls inside the stated range.
By their numbers in the Rattus norvegicus assay, from the lowest: compounds 1, 3 and 2 (each within the scatter of the next).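

In the Rattus norvegicus assay the swap on an amine nitrogen now has a measured size, a 1.2-fold lower number from compound 2 to compound 3 (0.09 log units; within the scatter), so putting a group with 2 hydrogen-bond donors in place of one with 1 hydrogen-bond donor at this place does not move the reading beyond the scatter. In a physicochemical assay for solubility, read by HPLC, in phosphate buffer, with a stated time of 20 min, at pH 2.0 (a lower number here means a less soluble compound, a higher number a more soluble compound), compound 2 reads > 50000000 nM, which is a limit of the assay and not a number. In the physicochemical assay compound 3 reads > 50000000 nM, also a limit, so the step in solubility cannot be read: the limit of > 50000000 nM in the physicochemical assay, at which 2 of the 2 values shown sit.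

Going by these compounds, what a different group on this amine nitrogen, such as a longer chain or a carboxylic acid, would do in the Rattus norvegicus assay remains open. On these data alone, compound 1 differs from compound 2 in more than one place, so the share of each difference also remains open.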